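Aryl amides: a dichloro variant of compound 1

The compounds below may be only part of what the source reports. "The series", "measured", "known", "first", "only" and "open" are said of these compounds alone.

Measured so far:
compound 1 `CC(C)Cc1ccc(C(C)C(=O)NCc2ccc(F)cc2)cc1`: 27000 nM
compound 2 `CC(C)Cc1ccc(C(C)C(=O)NCc2ccc(C(C)(C)C)cc2)cc1`: 25000 nM
compound 3 `CC(C)Cc1ccc(C(C)C(=O)NCc2cccc(C(F)(F)F)c2)cc1`: 28000 nM

In an assay on brain for inhibition of Fatty-acid amide hydrolase 1 (Rattus norvegicus), read by scintillation counting, with a stated time of 10 min (a higher number here means a weaker inhibitor, a lower number a stronger inhibitor), compound 1 gives 27000 nM, sitting with compound 3 at 28000 nM and compound 2 at 25000 nM; the three numbers lie within the scatter of one another. Compound 4 `CC(C)Cc1ccc(C(C)C(=O)NCc2ccc(Cl)c(Cl)c2)cc1` carries 3,4-dichlorophenyl in place of 4-fluorophenyl on a saturated chain carbon bound to an amide-type nitrogen. Among the measured compounds shown here, the only measured step on that ring, a 1.1-fold lower number from compound 1 to compound 2 (0.03 log units; within the scatter), swapped one group for another without moving the number beyond the scatter, and compound 3, bearing a trifluoromethyl on the same ring, sits in the same band. For the measured compounds named here, no measured step involves a chloro or a doubly substituted ring, so no direction can be read from the data. Compound 4 is therefore expected at about 25000 nM, within 10000 nM to 60000 nM, which means an expected 1.1-fold lower number from compound 1 to compound 4 (0.03 log units; within the scatter).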

Compound 4, half-maximal inhibitory concentration: 36000 nM
Compound 4: the middle estimate sits 1.4-fold (0.16 log units) below what was measured, and the stated range covers the measured number.
By their numbers in this assay, from the lowest: compounds 2, 1, 3 and 4 (each within the scatter of the next).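

In this assay, 3,4-dichlorophenyl in place of 4-fluorophenyl on a saturated chain carbon bound to an amide-type nitrogen gives a 1.3-fold higher number from compound 1 to compound 4 (0.12 log units; within the scatter). A ring carrying two chloro groups therefore stays within the scatter of compound 1, so this change adds a second substituent and a different halogen without a readable shift. No supporting data bear on this result. On these data alone, it remains open whether any group on this ring can move the number beyond the scatter, for example an amine or a carboxylic acid.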